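Sulfonyl aryl swaps in a piperidinyl-piperidine sulfonamide series

The source may report more compounds than this note shows. Statements on the series, on what has been measured and on what is new or still open speak of the compounds shown alone.

Measured so far:
compound 1 `CC1CCN(C2CCN(S(=O)(=O)c3ccc(C(C)(C)C)cc3)CC2)CC1` — > 5000 nM
compound 2 `CC1CCN(C2CCN(S(=O)(=O)c3cccnc3Cl)CC2)CC1` — > 5000 nM
compound 3 `CC1CCN(C2CCN(S(=O)(=O)c3ccc(Br)cc3OC(F)(F)F)CC2)CC1` — 5 nM

In a functional assay on DLD-1 cells (Homo sapiens) for antiproliferative activity, read by CellTiter-Glo, with a stated time of 72 h (a lower number here means a stronger inhibitor, a higher number a weaker inhibitor), compound 1 gives > 5000 nM, which is a limit of the assay and not a number. Compound 2 gives > 5000 nM in this assay, again a limit rather than a number. Compound 3, by contrast, gives 5 nM in this assay. Compound 2 therefore stands at the weak end of what has been seen: of the three values, two sit at the limit of > 5000 nM in this assay, at which 2 of the 3 values shown sit, and compound 2 is one of them, so its true potency is only known to lie beyond that boundary.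

Compound 4 `CC1CCN(C2CCN(S(=O)(=O)c3ccccc3Br)CC2)CC1` has not yet been measured in this assay. Against compound 2 it differs in one place: 2-bromophenyl in place of 2-chloropyridin-3-yl on a sulfonyl sulfur. For the measured compounds named here, no pair of measured compounds differs in a single place, so no measured step sets a scale for this change. Going by the values given here, what the numbers show is that the one aryl group carrying a ring nitrogen and a chlorine, compound 2, stays at the limit, while the carbon-only ring of compound 3, bearing a bromine and a trifluoromethoxy group, reaches low nanomolar potency; compound 1, also carbon-only, stays at the limit. A gain in this assay is expected for compound 4, with wide uncertainty, as the step of an at least 2.5-fold lower number from compound 2 to compound 4 (0.39 log units; beyond the scatter) from compound 2. Compound 4 is estimated at 2000 nM, within 200 nM to 10000 nM.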

Compound 4, half-maximal inhibitory concentration: 3 nM
Estimate against measurement, compound 4: 670-fold (2.82 log units) above; the measured number lies below the stated range.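

For the compounds shown here, on the sulfonyl sulfur, 2-bromophenyl in place of 2-chloropyridin-3-yl gives in this assay an at least 1600-fold lower number from compound 2 to compound 4 (3.22 log units; beyond the scatter), the only step so far between measured compounds that differ in one place. With the rest of the core held constant, this exchange of one aryl group on the sulfonyl sulfur is enough to carry a compound from the limit of this assay to strong inhibition, so this position is highly sensitive to the aryl group it carries. The true size of the step stays open because compound 2 gives > 5000 nM, a limit and not a number: the limit of > 5000 nM in this assay, at which 2 of the 4 values shown sit.

The exchange removes the ring nitrogen and replaces chlorine with bromine in a single move, so the compounds shown cannot tell which of the two changes carries the step; 2-chlorophenyl and 2-bromopyridin-3-yl would separate them. Equally open, going by these compounds, is how far the bromine itself matters, which a plain phenyl ring, or a methoxy group or an amine in the place of the bromine, would address in this assay.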